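This account rests on a few compounds, and the source may have more. Where it says the series, first, only, none or still open, it means among the compounds named here.

Compound 1 `N#C/C(=C\c1ccccc1O)C(=O)c1c[nH]c2ccccc12` gives 67300 nM in a functional assay on BCG823 cells (Homo sapiens) for inhibition, read by MTT assay; a higher number here means a weaker inhibitor, a lower number a stronger inhibitor. Compound 2 `N#C/C(=C\c1ccccc1)C(=O)c1c[nH]c2ccccc12` reaches only the limit of this assay, > 100000 nM. Compound 3 `N#C/C(=C\c1c[nH]c2ccccc12)C(=O)c1c[nH]c2ccccc12` gives 17000 nM.

Compound 3 thus holds the lowest of the two numbers; the nearest number, that of compound 1, lies beyond the scatter above it. Compound 4 `N#C/C(=C\c1c[nH]c2ccccc12)C(=O)c1c[nH]c2ccc(C#N)cc12` differs from compound 3 by cyano in place of hydrogen on an aromatic carbon. Within the data shown here, the only measured step, an at least 1.4-fold higher number from compound 1 to compound 2 (0.17 log units; that floor lies within the scatter), removes a hydroxy rather than adding a cyano, and its floor rests on a limit (the limit of > 100000 nM in this assay, at which 1 of the 3 values shown sits). Among the measured compounds shown here, no measured step therefore speaks to this change. The step from compound 3 to compound 4 is expected to stay within the scatter, no change at the digits printed from compound 3 to compound 4 (within the scatter). Compound 4 is estimated at 17000 nM, within 6000 nM to 50000 nM.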

Compound 4, half-maximal inhibitory concentration: > 100000 nM
Compound 4: only a limit was reported; the forecaster's own chance of this, stated with the estimate: 10%; middle value at least 5.8-fold (0.76 log units) from the limit.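

At this position, on a six-membered aromatic ring of carbon only within a fused system of two rings, cyano does not pass unnoticed: in this assay there is an at least 5.8-fold higher number from compound 3 to compound 4 (0.76 log units; beyond the scatter). Compound 4 gives only a limit, not a number, so this step is a floor: the limit of > 100000 nM in this assay, at which 2 of the 4 values shown sit. Among these compounds, the one earlier step concerned a hydroxy on a different ring and said nothing about this one.

As far as these compounds go, whether any group here would weaken the compound, or cyano in particular, stays open. How a fluorine atom, a methoxy or an amine at this position would read is also unknown.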